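From isopropylcarbonyl to propyl on an aromatic oxygen

A few compounds are considered here, and "the series" means these few. Any claim that something is new, unique, unknown or untested is made for them only; others in the source may bear on it.

In a functional assay on A549 cells (Homo sapiens) for cytotoxicity, with a stated time of 48 h (a higher number here means a weaker inhibitor, a lower number a stronger inhibitor), compound 1 `C[S+]([O-])/C=C/c1cc(=O)c2ccccc2o1` gives 1900 nM and compound 2 `CC(C)C(=O)Oc1ccc2oc(/C=C/[S+](C)[O-])cc(=O)c2c1` gives 2400 nM so compound 2 stands level with compound 1 within the scatter. Compound 3 `CCCOc1ccc2oc(/C=C/[S+](C)[O-])cc(=O)c2c1` carries propyl in place of isopropylcarbonyl on an oxygen on an aromatic ring. Among the compounds with values here, the one measured step of a 1.3-fold higher number from compound 1 to compound 2 (0.10 log units; within the scatter) put (isopropylcarbonyl)oxy in place of hydrogen on an aromatic carbon, so in this assay no step beyond the scatter is expected for this new change. The expected move is a 1.1-fold lower number from compound 2 to compound 3 (0.04 log units; within the scatter) only. Compound 3 is estimated at 2200 nM (800 nM to 6000 nM).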

Compound 3, half-maximal inhibitory concentration: 1100 nM
Compound 3: the middle estimate sits 2.0-fold (0.30 log units) above what was measured, and the stated range covers the measured number.
By their numbers in this assay, from the lowest: compounds 3, 1 and 2 (each within the scatter of the next, the first and the last beyond it).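

In this assay, the choice of group on this aromatic oxygen does register: propyl in place of isopropylcarbonyl gives a 2.2-fold lower number from compound 2 to compound 3 (0.34 log units; beyond the scatter), a modest change and the only step among these compounds beyond the scatter. Against the unsubstituted core, however, propoxy gives a 1.7-fold lower number from compound 1 to compound 3 (0.24 log units; within the scatter), so neither group separates clearly from hydrogen. As far as these compounds go, whether a longer chain such as butoxy, or an amine at this place, would move the number further remains open. Nothing available here explains the difference between compound 2 and compound 3.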